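The source may hold more compounds than are shown below. What is called first, only, known or untested is meant among the compounds shown, and "the series" means these compounds.

Measured so far in a functional assay on the whole organism for antagonist activity, with Mus musculus as the target (on this read-out higher numbers stand for an effect only at larger amounts of compound and lower numbers for an effect already at smaller amounts), every entry a limit and not a number:
- compound 1 `Cn1c(-c2cccs2)nnc1[S+](C)[O-]`: > 200 mg/kg
- compound 2 `CCSc1nnc(-c2ccccc2)n1C`: > 200 mg/kg
- compound 3 `CC[S+]([O-])c1nnc(-c2ccccc2)n1C`: > 200 mg/kg

Compound 3 stands at a limit, > 200 mg/kg, and has no number of its own. The same holds across the series: the limit of > 200 mg/kg in this assay, at which 3 of the 3 values shown sit.

Compound 4 `CC[S+]([O-])c1nnc(-c2ccccc2F)n1C` differs from compound 3 by fluoro in place of hydrogen on an aromatic carbon, ortho to a large group: fluoro in place of hydrogen on an aromatic carbon.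

Going by the values given here, the only measured step, a step that the two limits leave unreadable from compound 2 to compound 3, concerns another group and offers no size to carry over. Among the compounds with values here, no measured pair contains a fluoro change, so the data fix neither the size nor the direction of this step in this assay. The expectation therefore starts from the limit of compound 3, > 200 mg/kg, which does not show how far that compound lies from a number. Compound 4 may stay at the limit or may give a number, and the range is kept wide for that reason.

The expected change is an at least 1.3-fold lower number from compound 3 to compound 4 (0.12 log units; that floor lies within the scatter), and this estimate is only loosely held. For compound 4 the estimate is 150 mg/kg, with an expected range from 40 mg/kg to 400 mg/kg.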

Compound 4, dose for half-maximal effect: > 200 mg/kg
Compound 4 ended at the assay's limit; the forecaster's own chance of this, stated with the estimate: 45%; middle value at least 1.3-fold (0.12 log units) away from the limit.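

No step can be read between compound 3 and compound 4, as both entries are limits and not numbers, so the fluoro in place of hydrogen has no readable size. The compounds shown leave open whether any change to the shared core gives a number at all, with the whole series sitting at one value: the limit of > 200 mg/kg in this assay, at which 4 of the 4 values shown sit.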